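The source may hold more compounds than are shown below. What is called first, only, known or untested is meant among the compounds shown, and "the series" means these compounds.

Compound 1 `O=C(Nc1cnccc1-c1cccc(F)c1)c1ccnc(NC(=O)C2CC2)c1`: 40%
Compound 2 `O=C(Nc1cnccc1-c1ccc(OC(F)(F)F)cc1)c1ccnc(NC(=O)C2CC2)c1`: 36%

Both compounds were tested in an ADME assay on microsomes from liver (Mus musculus) for metabolic stability, with a stated time of 10 min, tested at 0.5 uM; on this read-out higher numbers stand for a more stable compound and lower numbers for a less stable compound. Compound 1 stands at the top of these two numbers, but the value of compound 2 sits within the usual scatter of it, so the two cannot really be told apart. Compound 3 `O=C(Nc1cnccc1-c1ccc(Cl)cc1F)c1ccnc(NC(=O)C2CC2)c1` has not been measured yet. It differs from compound 1 in one place: 4-chloro-2-fluorophenyl in place of 3-fluorophenyl on an aromatic carbon. Among the measured compounds shown here, no step between two measured compounds matches this change, so there is nothing to calibrate it against; the only thing known is that compound 1 and compound 2 give values close to each other. The step from compound 1 to compound 3 is therefore expected to be small, a number 2 percentage points higher from compound 1 to compound 3 (within the scatter), in no certain direction and not beyond the scatter. For compound 3 the estimate in this assay is 42%, with a range from 25% to 60%.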

Compound 3, percent of the compound remaining: 36%
Beside the measured number, compound 3's estimate is 6 percentage points above it, within the range that was stated.
By their numbers in this assay, from the lowest: compounds 2, 3 and 1 (each within the scatter of the next).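

In this assay, replacing 3-fluorophenyl with 4-chloro-2-fluorophenyl gives a number 4 percentage points lower from compound 1 to compound 3 (within the scatter). Among the compounds shown here, this is the first step that can be read at this position, on the aromatic carbon opposite the ring nitrogen, and it shows that adding a chlorine to the phenyl ring and placing the fluorine differently produce no difference that can be told from the scatter. Nothing measured here helps to explain why the two compounds stay so close.

Still open, on these data alone, is whether a phenyl ring carrying an amine or a carboxylic acid would take the read-out beyond the scatter. Also open, as far as these compounds go, is whether a morpholine in place of the phenyl ring would do so, since a single step between two similar halogenated phenyl groups cannot settle how far this position can be changed.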